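Swapping piperidin-1-yl for 4-methylpiperazin-1-yl at the assay limit

A few compounds are considered here, and "the series" means these few. Any claim that something is new, unique, unknown or untested is made for them only; others in the source may bear on it.

Of the compounds shown here, two have been tested so far in an ADME assay on SH-SY5Y cells (Homo sapiens) for cytotoxicity, read by MTT assay, with a stated time of 72 h; on this read-out lower numbers stand for higher toxicity in this test and higher numbers for lower toxicity in this test. In that test, compound 1 `c1ccc(Nc2cc(CNCCN3CCCCC3)cc(CNCCN3CCCCC3)c2)c(CN2CCCCC2)c1` gives > 100000 nM, which is a limit of the assay and not a number. Compound 2 `c1ccc(-c2cc(CNCCN3CCCCC3)cc(CNCCN3CCCCC3)c2)c(CN2CCCCC2)c1` gives > 100000 nM, again a limit and not a number. Compound 2 therefore has no exact value and stands with compound 1 at the limit of > 100000 nM in this assay, at which 2 of the 2 values shown sit, so the two cannot be ranked against each other.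

Compound 3 `CN1CCN(Cc2ccccc2-c2cc(CNCCN3CCCCC3)cc(CNCCN3CCCCC3)c2)CC1` has not yet been measured. It departs from compound 2 in one place: 4-methylpiperazin-1-yl in place of piperidin-1-yl on a saturated chain carbon bound to an aromatic carbon. In words, 4-methylpiperazin-1-yl takes the place of piperidin-1-yl on a saturated chain carbon bound to an aromatic carbon. Among the measured compounds shown here, no measured step between compounds shows what such a change does in this assay, so the expectation rests only on compound 2 and its limit of > 100000 nM. The step of a number no higher from compound 2 to compound 3 (the limit leaves the size open) is expected to stay within the usual scatter, with no direction foreseen. For compound 3 the estimated value is 100000 nM, with an expected range from 40000 nM to 250000 nM.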

Compound 3, half-maximal cytotoxic concentration: > 100000 nM
Compound 3: only a limit was reported (the forecaster's own chance of this, stated with the estimate: 75%); the middle value sits exactly at the limit.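

In this assay compound 3 gives > 100000 nM, which is a limit of the assay and not a number. Compound 2 also has only a limit, so the step from piperidin-1-yl to 4-methylpiperazin-1-yl between compound 2 and compound 3 cannot be read. The compounds shown leave open where their true values lie and whether they differ at all: the limit of > 100000 nM in this assay, at which 3 of the 3 values shown sit.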